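Methoxy for Fluoro on the Benzyl Ring of Compound 2

This account rests on a few compounds, and the source may have more. Where it says the series, first, only, none or still open, it means among the compounds named here.

Within the data shown here, in a functional assay on COLO 205 cells (Homo sapiens) for inhibition, read by sulforhodamine B assay, with a stated time of 48 h (on this read-out lower numbers stand for stronger inhibition of growth and higher numbers for weaker inhibition of growth), compound 2, `Nc1cc(N)c2nc(-c3ccccc3)c(NCc3ccc(F)cc3)nc2c1`, gives 6170 nM, the only number among the values shown. Compound 1, `COc1ccc(CNc2nc3cc(N)cc(N)c3nc2-c2ccccc2)cc1OC`, gives < 100000 nM in this assay, which is a limit and not a number. The step that the limit leaves unreadable from compound 1 to compound 2 therefore cannot be read, as the limit of < 100000 nM in this assay, at which 1 of the 2 values shown sits, marks it. Compound 3, `COc1ccc(CNc2nc3cc(N)cc(N)c3nc2-c2ccccc2)cc1`, differs from compound 2 by methoxy in place of fluoro on an aromatic carbon. Among the measured compounds shown here, no measured step bears on this change: the one comparison made, from compound 1 to compound 2, carries a limit, and compound 1 differs at two places at once. In this assay compound 3 is therefore expected to sit near compound 2, the expected step of a 1.0-fold lower number from compound 2 to compound 3 (0.01 log units; within the scatter) lying within the scatter. The estimate for compound 3 in this assay is 6000 nM, expected between 2000 nM and 20000 nM.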

Compound 3, concentration for total growth inhibition: 33900 nM
Compound 3: the middle estimate sits 5.7-fold (0.75 log units) below what was measured; measured number outside the range, above it.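

Going from 4-fluorobenzyl to 4-methoxybenzyl on the shared core gives, in this assay, a 5.5-fold higher number from compound 2 to compound 3 (0.74 log units; beyond the scatter), and this is the first step at this position that can be read. On this read-out a higher number stands for weaker inhibition of growth, so the group at this place matters, and here methoxy goes with weaker inhibition than fluoro. The steps that start from compound 1 cannot be read, as the value of compound 1 is a limit and not a number: the limit of < 100000 nM in this assay, at which 1 of the 3 values shown sits.

The compounds shown leave open how a chlorine atom, a hydroxyl or an amine would fare at this place, and where the plain benzyl group would stand relative to compound 2 and compound 3. Going by these compounds, whether the same exchange would carry a step of like size with a group other than phenyl on the core also stays open.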